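Hydroxyphenyl isomers on the shared core

A few compounds are considered here, and "the series" means these few. Any claim that something is new, unique, unknown or untested is made for them only; others in the source may bear on it.

Among the measured compounds shown here, compound 2 `Oc1cccc(-c2cc(-c3cccs3)cc(-c3cccc(O)c3)n2)c1` is the only member of the series with a number in a functional assay on T47D cells (Homo sapiens) for cytotoxicity, read by CCK-8 assay (on this read-out higher numbers stand for weaker inhibition and lower numbers for stronger inhibition), where compound 2 gives 770 nM. Compound 1 `Oc1cccc(-c2cc(-c3cccs3)cc(-c3ccccc3O)n2)c1` returns only a limit in this assay, > 50000 nM. For the measured compounds named here, the one measured step, an at least 64-fold lower number from compound 1 to compound 2 (1.81 log units; beyond the scatter), shows that moving the hydroxyl on this phenyl is far from neutral; since the starting point is the limit (the limit of > 50000 nM in this assay, at which 1 of the 2 values shown sits), the true size of that step is not known. Compound 3 `Oc1ccc(-c2cc(-c3cccs3)cc(-c3cccc(O)c3)n2)cc1` differs from compound 2 by 4-hydroxyphenyl in place of 3-hydroxyphenyl on an aromatic carbon. Going by the values given here, no measured step covers this change directly; the step from compound 1 to compound 2 only shows that the hydroxyl position on this ring matters. The expected outcome is therefore a somewhat higher number with a broad range, an expected step of a 1.9-fold higher number from compound 2 to compound 3 (0.29 log units; within the scatter). Compound 3 is expected to give about 1500 nM, between 300 nM and 10000 nM.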

Compound 3, half-maximal inhibitory concentration: 780 nM
Estimate against measurement, compound 3: 1.9-fold (0.28 log units) above, and the stated range covers the measured number.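

In this assay, 4-hydroxyphenyl in place of 3-hydroxyphenyl gives a 1.0-fold higher number from compound 2 to compound 3 (0.01 log units; within the scatter), so these two hydroxyl placements on this phenyl cannot be told apart. The large separation therefore does not belong to compound 2 alone: 2-hydroxyphenyl in compound 1 stands apart from the 4-hydroxyphenyl as well, with an at least 64-fold lower number from compound 1 to compound 3 (1.80 log units; beyond the scatter). The value of compound 1 is a limit and not a number, and the true size of this step stays unknown: the limit of > 50000 nM in this assay, at which 1 of the 3 values shown sits.

Still open, going by these compounds, is whether the hydroxyl itself is required on this phenyl, or whether a methoxy group or an amine in its place would keep the number near those of compound 2 and compound 3. Also open, on these data alone, is how a carboxylic acid on this ring, or a replacement of the thiophen-2-yl group, would read.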